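Methyl to fluoro on the aryl ring: an untested swap

This account rests on a few compounds, and the source may have more. Where it says the series, first, only, none or still open, it means among the compounds named here.

Compound 1 `Oc1nc2nonc2nc1Nc1ccc(OCC(F)(F)F)cc1` — 42300 nM
Compound 2 `Cc1cc(Nc2nc3nonc3nc2O)ccc1OCC(F)(F)F` — 7000 nM

In an assay on mitochondria from L6 cells (Rattus norvegicus) for activation, with a stated time of 90 min (on this read-out higher numbers stand for an effect only at larger amounts of compound and lower numbers for an effect already at smaller amounts), compound 2 has the lower of the two numbers, and compound 1 stands a 6.0-fold lower number from compound 1 to compound 2 (0.78 log units; beyond the scatter) away from it. Among the compounds with values here, the one measured step shows that methyl in place of hydrogen moved the read-out beyond the scatter, by a modest amount.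

Compound 3 `Oc1nc2nonc2nc1Nc1ccc(OCC(F)(F)F)c(F)c1` carries the change (fluoro in place of methyl on an aromatic carbon). Within the data shown here, no measured step involves a fluoro group, so the only bearing evidence is the step of a 6.0-fold lower number from compound 1 to compound 2 (0.78 log units; beyond the scatter), which says what methyl added and therefore what its removal might cost. On these data alone, whether fluoro recovers any of that is unknown. The account therefore expects compound 3 to land between the two measured compounds, with a step of a 2.9-fold higher number from compound 2 to compound 3 (0.46 log units; beyond the scatter) in this assay taken as the estimate. Compound 3 is estimated at 20000 nM, within a range from 6000 nM to 60000 nM.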

Compound 3, half-maximal effective concentration: 10400 nM
Compound 3: middle estimate off by 1.9-fold (0.28 log units), on the high side; measured number inside the range.
By their numbers in this assay, from the lowest: compounds 2 and 3 (each within the scatter of the next); then compound 1.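

In this assay the place ortho to a 2,2,2-trifluoroethoxy group now answers to a second group: fluoro in place of hydrogen gives a 4.1-fold lower number from compound 1 to compound 3 (0.61 log units; beyond the scatter) and that modest step shows that the shift away from hydrogen is not confined to methyl. Fluoro in place of methyl gives a 1.5-fold higher number from compound 2 to compound 3 (0.17 log units; within the scatter) and so, at this place and on this read-out, the two groups cannot be told apart. Nothing measured here speaks to the reason for this result.

On these data alone, whether the same holds for other groups at this place, such as chloro, methoxy or an amine, stays open. Also open, as far as these compounds go, is whether these steps would persist if a longer chain replaced the 2,2,2-trifluoroethoxy group.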